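The compounds below may be only part of what the source reports. "The series", "measured", "known", "first", "only" and "open" are said of these compounds alone.

Measured compounds:
- Compound 1 `O=C1CC(=C(c2ccccc2)c2ccccc2)C(=O)N1CN1CCN(c2ccc(F)cc2)CC1`, in an assay on membranes from Cerebral cortex for binding affinity to Adrenergic receptor alpha-1 (Rattus norvegicus), read by radioligand binding (a lower number here means a stronger inhibitor, a higher number a weaker inhibitor), compound 1 gives 746 nM.
- Compound 2 `O=C1CC(=C(c2ccccc2)c2ccccc2)C(=O)N1CCN1CCN(c2ccccc2)CC1`, in this assay compound 2 gives 214 nM.

Compound 2 stands with the lower of the two numbers. The nearest measured point is compound 1, whose number is higher by a margin that lies beyond the usual scatter. Among the compounds with values here, the two measured compounds differ in more than one place, so no single-point step between them can be drawn; they only show that the two-carbon linker compound with the plain phenyl ring has the stronger figure of the pair.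

Compound 3 `O=C1CC(=C(c2ccccc2)c2ccccc2)C(=O)N1CCN1CCN(c2ccc(F)cc2)CC1` is not yet measured. Against compound 2 the change is fluoro in place of hydrogen on an aromatic carbon, with the linker of compound 2 kept. Nothing in the measured pair isolates this one change. The expectation is for no step beyond the scatter, with at most a slight drift toward a higher number. Compound 3 is therefore estimated at 260 nM, within 100 nM to 650 nM, which means an expected step of a 1.2-fold higher number from compound 2 to compound 3 (0.08 log units; within the scatter).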

Compound 3, inhibition constant: 529 nM
Compound 3: the middle estimate sits 2.0-fold (0.31 log units) below what was measured; the range from low to high includes it.
By their numbers in this assay, from the lowest: compound 2; then compounds 3 and 1 (each within the scatter of the next).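

In this assay, the phenyl to 4-fluorophenyl change can now be read on its own with the linker held constant: it gives a 2.5-fold higher number from compound 2 to compound 3 (0.39 log units; beyond the scatter), so this position, para to a large group, does respond to fluoro in place of hydrogen, and the plain phenyl ring carries the lower number of the pair. Compound 3 shares its 4-fluorophenyl with compound 1 and differs from it only in the linker, yet compound 3 at 529 nM and compound 1 at 746 nM lie within the scatter of each other, so with this ring in place the pair shows no readable linker effect. Nothing available explains the step caused by the fluoro group, and the reading stays purely empirical.

Still open, as far as these compounds go, is whether chloro or methoxy at the same position moves the number in the same direction as fluoro, or whether this step is particular to fluoro. Also open, from the compounds shown here alone, are how the linker of compound 1 behaves with the plain phenyl ring and what a longer chain in the linker does with either ring.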